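The source may hold more compounds than are shown below. What is called first, only, known or untested is meant among the compounds shown, and "the series" means these compounds.

Measured so far:

Compound 1, `Clc1ccc(Cc2nn3c(Br)c(-c4ccccc4)nc3s2)cc1`. In a functional assay on HeLa cells (Homo sapiens) for cytotoxicity, with a stated time of 72 h (a lower number here means a stronger inhibitor, a higher number a weaker inhibitor), compound 1 gives only a limit, > 250000 nM.
Compound 2, `O=[N+]([O-])c1ccc(-c2nc3sc(Cc4ccc(Cl)cc4)nn3c2Br)cc1`. In this assay compound 2 likewise gives only a limit, > 250000 nM.
Compound 3, `O=Cc1c(-c2ccccc2)nc2sc(Cc3ccc(Cl)cc3)nn12`. In this assay, within the data shown here, compound 3 gives 45000 nM, the single numeric value in the set.

Two single-point changes connect the measured compounds. From compound 1 to compound 3 the change is formyl in place of bromo on an aromatic carbon, and in this assay it gives an at least 5.5-fold lower number from compound 1 to compound 3 (0.74 log units; beyond the scatter). From compound 1 to compound 2 the change is nitro in place of hydrogen on an aromatic carbon; the step that the two limits leave unreadable from compound 1 to compound 2 cannot be sized because of the limit of > 250000 nM in this assay, at which 2 of the 3 values shown sit.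

Compound 4, `O=Cc1c(-c2ccc([N+](=O)[O-])cc2)nc2sc(Cc3ccc(Cl)cc3)nn12`, is not yet measured. It differs from compound 3 by nitro in place of hydrogen on an aromatic carbon, the same kind of change as that from compound 1 to compound 2; the two place descriptions are identical word for word. The two cores differ by formyl in place of bromo on an aromatic carbon.

The earlier instance of this change gives no readable size, so the expectation for compound 4 rests mainly on compound 3 and its 45000 nM, with a wide band around it. In this assay compound 4 is expected to show a step of a 1.3-fold higher number from compound 3 to compound 4 (0.12 log units; within the scatter), which is to say little net change within the uncertainty. The estimate for compound 4 in this assay is 60000 nM, expected to fall between 15000 nM and 250000 nM.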

Compound 4, half-maximal inhibitory concentration: 17000 nM
Estimate against measurement, compound 4: 3.5-fold (0.55 log units) above; measured number inside the range.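

In this assay, nitro in place of hydrogen on an aromatic carbon, phenyl to 4-nitrophenyl on the formyl-bearing core, gives a 2.6-fold lower number from compound 3 to compound 4 (0.42 log units; beyond the scatter), so on this core the change has a readable size and lowers the number. The same change on the bromo-bearing core cannot be read, so the data do not show whether that size carries over from one core to the other: the limit of > 250000 nM in this assay, at which 2 of the 4 values shown sit.

Formyl in place of bromo with the 4-nitrophenyl group present gives an at least 14-fold lower number from compound 2 to compound 4 (1.16 log units; beyond the scatter), and this change lowers the number on both cores, although its size on one core cannot be set firmly against its size on the other: the same change on two cores in this assay, an at least 5.5-fold lower number (0.74 log units; beyond the scatter) from compound 1 to compound 3 and an at least 14-fold lower number (1.16 log units; beyond the scatter) from compound 2 to compound 4; the limit leaves it open whether they differ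

Still open, on these data alone, is whether an amine or a carboxylic acid in the place of the nitro group would also lower the number on the formyl-bearing core. Also open, as far as these compounds go, is whether the step from bromo depends on the formyl group itself, which a hydroxymethyl group or a carboxylic acid at that carbon would begin to test.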